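A few compounds are considered here, and "the series" means these few. Any claim that something is new, unique, unknown or untested is made for them only; others in the source may bear on it.

Measured in a functional assay on SK-OV-3 cells (Homo sapiens) for antiproliferative activity, read by MTT assay, with a stated time of 24 h; a higher number here means a weaker inhibitor, a lower number a stronger inhibitor:
- compound 1 `COc1cccc(/C=C/C(=O)c2ccc(OC)c3c2OC(C)(C)C=C3)c1`: 9360 nM
- compound 2 `COc1ccc(C(=O)/C=C/c2ccc([N+](=O)[O-])cc2)c2c1C=CC(C)(C)O2`: 3420 nM

Compound 2, at 3420 nM, has the lower number of the pair, which makes it the stronger inhibitor in this assay. Compound 3 `COc1ccc(C(=O)/C=C/c2ccco2)c2c1C=CC(C)(C)O2` keeps the shared core and changes one group: furan-2-yl in place of 4-nitrophenyl on a double-bonded chain carbon bound to a double-bonded chain carbon. In words, furan-2-yl stands in place of 4-nitrophenyl on a double-bonded chain carbon bound to a double-bonded chain carbon.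

Within the data shown here, only one measured step bears on this place: a 2.7-fold lower number from compound 1 to compound 2 (0.44 log units; beyond the scatter). Among the measured compounds shown here, that modest step shows that a swap here can move the number beyond the scatter, but no measured compound carries furan-2-yl. A modest rise, giving back about what that step gained, is therefore expected. The expected change is a 1.8-fold higher number from compound 2 to compound 3 (0.24 log units; within the scatter). For compound 3, the estimate is 6000 nM, with an expected range of 2200 nM to 16000 nM.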

Compound 3, half-maximal inhibitory concentration: > 10000 nM
Compound 3: only a limit was reported (the forecaster's own chance of this, stated with the estimate: 10%); middle value at least 1.6-fold (0.22 log units) away from the limit.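

In this assay, compound 3 is reported only as a limit, not as a number: the limit of > 10000 nM in this assay, at which 1 of the 3 values shown sits. Even so, the limit is enough to show that this place can also lose ground, which the earlier pair, with its single gain, could not show: furan-2-yl in place of 4-nitrophenyl gives an at least 2.9-fold higher number from compound 2 to compound 3 (0.46 log units; beyond the scatter). The comparison with 3-methoxyphenyl is looser, with an at least 1.0-fold higher number from compound 1 to compound 3 (0.02 log units; that floor lies within the scatter), so compound 3 cannot be ranked against compound 1.

The compounds shown do not reveal how far past the limit compound 3 truly lies, nor whether the loss comes from leaving the six-membered ring or from losing the nitro group. From the compounds shown here alone, how an unsubstituted phenyl or a 4-aminophenyl would fare at this place also remains open.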